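A few compounds are considered here, and "the series" means these few. Any claim that something is new, unique, unknown or untested is made for them only; others in the source may bear on it.

In a functional assay on MCF7 cells (Homo sapiens) for antiproliferative activity, read by sulforhodamine B assay, with a stated time of 48 h (on this read-out lower numbers stand for stronger inhibition of growth and higher numbers for weaker inhibition of growth), the measured compounds are:
- compound 1 `O=C(NCCCNc1cc(-c2cn(-c3ccccc3)nc2-c2cccc(O)c2)ccn1)Nc1ccc(F)cc1` with 6040 nM as its value
- compound 2 `O=C(NCCCNc1cc(-c2cn(-c3ccccc3)nc2-c2cccc(O)c2)ccn1)Nc1cccc(C(F)(F)F)c1` with 9390 nM as its value

Within the data shown here, compound 1 holds one of only two numbers, and compound 2 lies within the scatter of it. Compound 3 `COc1cccc(-c2nn(-c3ccccc3)cc2-c2ccnc(NCCCNC(=O)Nc3ccc(F)cc3)c2)c1` is still unmeasured. Its change from compound 1 is methyl in place of hydrogen on an oxygen on an aromatic ring in full, methyl in place of hydrogen on an oxygen on an aromatic ring, or hydroxy to methoxy. Among the measured compounds shown here, the one measured change sits on an amide-type nitrogen, not on this oxygen, so a 1.6-fold higher number from compound 1 to compound 2 (0.19 log units; within the scatter) gives no direct measure of the new change, and the expectation starts from compound 1 at 6040 nM as its anchor. No step beyond the scatter is expected in this assay and no firm direction. The estimated step is a 1.2-fold higher number from compound 1 to compound 3 (0.09 log units; within the scatter) as an expectation only. Compound 3 is expected at 7500 nM with 3000 nM to 18000 nM as the estimated range.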

Compound 3, concentration for total growth inhibition: 18000 nM
Beside the measured number, compound 3's estimate is 2.4-fold (0.38 log units) below it; the measured number falls inside the stated range.
By their numbers in this assay, from the lowest: compounds 1, 2 and 3 (each within the scatter of the next, the first and the last beyond it).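

In this assay, among these compounds, the oxygen on the aromatic ring is the first place where a single change goes beyond the scatter: hydroxy to methoxy gives a 3.0-fold higher number from compound 1 to compound 3 (0.47 log units; beyond the scatter), a modest weakening of growth inhibition. Among the compounds shown here, the only earlier step, on the amide-type nitrogen, gave a 1.6-fold higher number from compound 1 to compound 2 (0.19 log units; within the scatter), so this oxygen is, on one pair of compounds, the more responsive of the two places. Nothing available bears on the reason for this step.

The compounds shown do not separate the loss of the hydrogen from the arrival of the methyl; an ethoxy, an amine or a fluorine in place of the hydroxy would address that. On these data alone, whether the step holds with the 3-(trifluoromethyl)phenyl group of compound 2 in place of 4-fluorophenyl also remains open.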